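Swapping One Side Chain on a Shared Core

The source may hold more compounds than are shown below. What is called first, only, known or untested is meant among the compounds shown, and "the series" means these compounds.

Measured in a functional assay on KETR3 cells (Homo sapiens) for inhibition, read by MTT assay, with a stated time of 120 h; on this read-out lower numbers stand for stronger inhibition and higher numbers for weaker inhibition:
- compound 1 `CNC(=O)/C=C/c1ccc(NC(=O)Nc2ccc(Cl)c(C(F)(F)F)c2)cc1` gives 21200 nM
- compound 2 `CNC(=O)c1cccc(-c2ccc(NC(=O)Nc3ccc(Cl)c(C(F)(F)F)c3)cc2)c1` gives 39300 nM
- compound 3 `CNC(=O)CCc1ccc(NC(=O)Nc2ccc(Cl)c(C(F)(F)F)c2)cc1` gives 24000 nM

Compound 3, at 24000 nM, lies within the scatter of both other compounds, so these values cannot be ranked. The next compound, compound 4 `CNC(=O)/C=C(\C)c1ccc(NC(=O)Nc2ccc(Cl)c(C(F)(F)F)c2)cc1`, alters the chain of compound 3: 1-methyl-2-(methylcarbamoyl)ethenyl in place of 2-(methylcarbamoyl)ethyl on an aromatic carbon. In words, this is 1-methyl-2-(methylcarbamoyl)ethenyl in place of 2-(methylcarbamoyl)ethyl on an aromatic carbon.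

The closest guide is the exchange of 2-(methylcarbamoyl)ethenyl for 2-(methylcarbamoyl)ethyl, which gave a 1.1-fold higher number from compound 1 to compound 3 (0.05 log units; within the scatter). The exchanges involving 3-(methylcarbamoyl)phenyl gave a 1.9-fold higher number from compound 1 to compound 2 (0.27 log units; within the scatter) and a 1.6-fold lower number from compound 2 to compound 3 (0.21 log units; within the scatter). Among these three compounds, then, changing this chain has produced no step beyond the scatter. Within the data shown here, no measured step isolates the added methyl, so that part remains untested. No step beyond the scatter is expected in this assay, in either direction. The estimated step is a 1.0-fold higher number from compound 3 to compound 4 (0.02 log units; within the scatter). Compound 4 is expected at 25000 nM, with an estimated range of 11000 nM to 50000 nM.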

Compound 4, half-maximal inhibitory concentration: > 50000 nM
Compound 4: only a limit was reported (the forecaster's own chance of this, stated with the estimate: 15%); middle value at least 2.0-fold (0.30 log units) away from the limit.
By their numbers in this assay, from the lowest: compounds 1, 3 and 2 (each within the scatter of the next). At a limit, above all of these: compound 4.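

In this assay compound 4 is recorded only as a limit of the assay, not as a number: the limit of > 50000 nM in this assay, at which 1 of the 4 values shown sits. Even so, this chain now gives steps beyond the scatter, an at least 2.0-fold higher number from compound 3 to compound 4 (0.31 log units; beyond the scatter) and an at least 2.3-fold higher number from compound 1 to compound 4 (0.37 log units; beyond the scatter), whereas compounds 1, 2 and 3 could not be ranked. The second step is the more telling, since compounds 1 and 4 differ only by the added methyl on the chain, so this small addition does weaken inhibition, while the comparison with the third compound stays unresolved: an at least 1.2-fold higher number from compound 2 to compound 4 (0.10 log units; that floor lies within the scatter).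

As far as these compounds go, the true size of the loss remains open, as a limit sets only a floor. Also open, from the compounds shown here alone, is how a 1-ethyl or 1-amino group in place of the 1-methyl, or a methyl added to the saturated chain of compound 3, would behave.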